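Moving the Amine Substituent: Compound 2 to Compound 3

The compounds below may be only part of what the source reports. "The series", "measured", "known", "first", "only" and "open" are said of these compounds alone.

Compound 1, `CCNCc1ccc(Cl)c(-c2ccccc2OC)c1`: > 10000 nM
Compound 2, `CCCCNCc1ccc(Cl)c(-c2ccccc2OC)c1`: > 10000 nM

In an assay on isolated protein for binding affinity to 5-hydroxytryptamine receptor 3A (Homo sapiens) (on this read-out lower numbers stand for stronger inhibition and higher numbers for weaker inhibition), compound 1 `CCNCc1ccc(Cl)c(-c2ccccc2OC)c1` gives only a limit, > 10000 nM. Compound 2 `CCCCNCc1ccc(Cl)c(-c2ccccc2OC)c1` likewise gives only a limit in this assay, > 10000 nM. The step that the two limits leave unreadable from compound 1 to compound 2 cannot be sized because of the limit of > 10000 nM in this assay, at which 2 of the 2 values shown sit. Compound 3 `CCN(CC)Cc1ccc(Cl)c(-c2ccccc2OC)c1` is not yet measured; it differs from compound 2 by diethylamino in place of butylamino on a saturated chain carbon bound to an aromatic carbon. Among the measured compounds shown here, no measured step of this kind exists, and the one measured step stays unreadable, so compound 3 is expected to give a limit as well, the step that the limit leaves unreadable from compound 2 to compound 3 being the expected outcome. Compound 3 is therefore estimated at 20000 nM, within 5000 nM to 80000 nM.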

Compound 3, inhibition constant: > 10000 nM
Compound 3: a limit, no number; the forecaster's own chance of this, stated with the estimate: 85%; the middle value lies beyond the limit too.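

Among the compounds shown here, no step among compound 1, compound 2 and compound 3 can be read, because all three stop at the same limit: the limit of > 10000 nM in this assay, at which 3 of the 3 values shown sit. Going by these compounds, whether any amine group on the shared core gives a readable number in this assay stays open.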